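Adding a formyl group to compound 3

The compounds below may be only part of what the source reports. "The series", "measured", "known", "first", "only" and "open" are said of these compounds alone.

Values in a functional assay on HCT-116 cells (Homo sapiens) for antiproliferative activity, read by MTT assay, with a stated time of 48 h (a lower number here means a stronger inhibitor, a higher number a weaker inhibitor), for the measured compounds:
- compound 1 `COc1cc(-c2nnc3c(OC)cc(-c4ccc5[nH]cc(C=O)c5c4)cn23)cc(OC)c1OC` gives > 10000 nM (a limit)
- compound 2 `CCOc1cc(-c2ccc3c(ccn3C)c2)cn2c(-c3cc(OC)c(OC)c(OC)c3)nnc12` gives 228 nM (a number)
- compound 3 `COc1cc(-c2nnc3c(OC)cc(-c4ccc5c(ccn5C)c4)cn23)cc(OC)c1OC` gives 33 nM (a number)

Compound 3 holds the lower of the two true numbers, with a 6.9-fold lower number from compound 2 to compound 3 (0.84 log units; beyond the scatter) leading to it. Compound 1 stands at the limit of > 10000 nM in this assay, at which 1 of the 3 values shown sits, and so offers a limit only.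

Compound 4 `COc1cc(-c2nnc3c(OC)cc(-c4ccc5c(c4)c(C=O)cn5C)cn23)cc(OC)c1OC` carries formyl in place of hydrogen on an aromatic carbon of compound 3. The change, (formyl in place of hydrogen on an aromatic carbon), has no exact measured match.

The closest measured step is an at least 300-fold lower number from compound 1 to compound 3 (2.48 log units; beyond the scatter) and it loses a formyl group while also gaining the methyl group, so the share of the formyl group cannot be separated. Compound 4 keeps that methyl group. The step of a 6.9-fold lower number from compound 2 to compound 3 (0.84 log units; beyond the scatter) concerns another part of the molecule and sets no size here.

A clear move to a higher number is therefore expected in this assay, probably smaller than the full step from the compound with the limit. The expected step is a 24-fold higher number from compound 3 to compound 4 (1.38 log units; beyond the scatter), in the weaker direction. For compound 4 the estimated value is 800 nM, with an expected range from 100 nM to 8000 nM in this assay as the read-out.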

Compound 4, half-maximal inhibitory concentration: 1800 nM
Compound 4: middle estimate off by 2.3-fold (0.35 log units), on the low side; measured number inside the range.
By their numbers in this assay, from the lowest: compound 3; then compound 2; then compound 4. At a limit, above all of these: compound 1.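

In this assay, formyl in place of hydrogen on an aromatic carbon now has a size of its own, separate from the methyl group on the ring nitrogen: a 55-fold higher number from compound 3 to compound 4 (1.74 log units; beyond the scatter). With the formyl group kept in both compounds, methyl in place of hydrogen on an aromatic nitrogen gives an at least 5.5-fold lower number from compound 1 to compound 4 (0.74 log units; beyond the scatter). Compound 1 stands at a limit, so this second step gives a minimum size only: the limit of > 10000 nM in this assay, at which 1 of the 4 values shown sits.

At this carbon the compounds shown carry only formyl and hydrogen, and how a hydroxymethyl group or an amine would read there stays open. Also open, on these data alone, is whether the formyl step keeps its size with the ethoxy group of compound 2 on the shared core.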